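A few compounds are considered here, and "the series" means these few. Any claim that something is new, unique, unknown or untested is made for them only; others in the source may bear on it.

Compound 1 `COc1ccc(S(=O)(=O)c2cnc3ccc(C)cc3c2N2CCC(C)CC2)cc1` gives 62%; compound 2 `COc1cccc(S(=O)(=O)c2cnc3ccc(OC)cc3c2N2CCC(C)CC2)c1` gives 0%; compound 3 `Cc1ccc2ncc(S(=O)(=O)c3ccc(F)c(Cl)c3)c(N3CCC(C)CC3)c2c1` gives 93%, all in an assay on isolated protein for displacement of a labelled ligand from metabotropic glutamate receptor 5 (Homo sapiens), with a stated time of 60 min, tested at 1 uM; a higher number here means more inhibition at the concentration tested (going by the name of the read-out), a lower number less inhibition.

Compound 3 stands highest of these three in this assay; the nearest, compound 1, is separated from it by the step of a number 31 percentage points higher from compound 1 to compound 3 (beyond the scatter), and compound 2 lies far lower still. Compound 4 `COc1cccc(S(=O)(=O)c2cnc3ccc(C)cc3c2N2CCC(C)CC2)c1` differs from compound 3 in one place: 3-methoxyphenyl in place of 3-chloro-4-fluorophenyl on a sulfonyl sulfur. Among the compounds with values here, the only measured step that bears on this swap is the one from compound 1 to compound 3, where a halogenated phenyl took the place of a methoxyphenyl and inhibition rose sharply. Reversing that kind of change here points to a drop of similar size, and compound 2, which also carries a 3-methoxyphenyl, gave 0%. The expected step is a number 58 percentage points lower from compound 3 to compound 4 (beyond the scatter). Compound 4 is therefore estimated at 35%, between 5% and 65%.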

Compound 4, a percentage reported as inhibition, at one concentration (the size of the read-out at that concentration, not a potency): 96%
The estimate for compound 4 lay 61 percentage points below the measured number, and the stated range ends below it.
By their numbers in this assay, from the lowest: compound 2; then compound 1; then compounds 3 and 4 (each within the scatter of the next).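

In this assay, 3-methoxyphenyl on the sulfonyl sulfur serves as well as 3-chloro-4-fluorophenyl, with a number 3 percentage points higher from compound 3 to compound 4 (within the scatter), while 3-methoxyphenyl in place of 4-methoxyphenyl gives a number 34 percentage points higher from compound 1 to compound 4 (beyond the scatter), so the place of the methoxy on this ring matters here. Compound 2 shares this 3-methoxyphenyl, yet methyl in place of methoxy on an aromatic carbon of the core gives a number 96 percentage points higher from compound 2 to compound 4 (beyond the scatter), which shows that this one change on the core can decide the result. No measured evidence here explains these differences.

As far as these compounds go, how an amine or a carboxylic acid on this phenyl ring would read remains open. Also open, from the compounds shown here alone, is whether methoxy on the core has the same effect alongside 3-chloro-4-fluorophenyl.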